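Stereoisomeric iminosugar acids against the cytosolic glycosidase

A few compounds are considered here, and "the series" means these few. Any claim that something is new, unique, unknown or untested is made for them only; others in the source may bear on it.

Measured so far:
compound 1 `O=C(O)[C@H]1NC[C@H](O)[C@H](O)[C@H]1O`: 7.6%
compound 2 `O=C(O)[C@H]1NC[C@@H](O)[C@@H](O)[C@@H]1O`: 28%
compound 3 `O=C(O)[C@H]1NCC=C[C@@H]1O`: 60%

Three compounds have been run in an assay on isolated protein for inhibition of cytosolic endo-beta-N-acetylglucosaminidase (Homo sapiens), tested at 1000 uM; on this read-out lower numbers stand for less inhibition and higher numbers for more inhibition at the one concentration tested (going by the name of the read-out). Compound 3 gives 60%, the highest of the set. Compound 2 stands second with 28%; it is beyond the scatter above compound 1 and beyond the scatter below compound 3.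

Going by the values given here, the one measured step is a number 20.4 percentage points higher from compound 1 to compound 2 (beyond the scatter). It rests on (the fact that compounds 1 and 2 differ only in the configuration as drawn), so configuration alone moves the read-out by a modest amount in this set.

Compound 4 `O=C(O)[C@@H]1NC[C@H](O)[C@@H](O)[C@H]1O` is the next member. Relative to compound 2, (the two compounds have the same atoms and bonds and differ only in configuration as drawn: 3 of 4 stereo elements differ; a stereocentre at a saturated ring carbon is drawn S in compound 2 and R in compound 4; a stereocentre at a saturated ring carbon is drawn R in compound 2 and S in compound 4; a stereocentre at a saturated ring carbon is drawn R in compound 2 and S in compound 4). Among the compounds with values here, the step from compound 1 to compound 2 is the only guide, and it shows that inverting several ring stereocentres can shift the read-out by a modest amount in either direction, with no way to tell the direction for compound 4 from the data. Given that compound 2 sits between the two other values, the expected step of a number 10 percentage points lower from compound 2 to compound 4 (within the scatter) is taken as a modest decrease, with wide uncertainty. Compound 4 is therefore expected to give about 18%, estimated between 3% and 45%.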

Compound 4, a percentage reported as inhibition, at one concentration (the size of the read-out at that concentration, not a potency): 42%
Compound 4: middle estimate off by 24 percentage points, on the low side; the range from low to high includes it.
By their numbers in this assay, from the lowest: compound 1; then compound 2; then compound 4; then compound 3.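

The new stereoisomer gives a read-out in this assay that is a number 14 percentage points higher from compound 2 to compound 4 (beyond the scatter), so this upward step comes from configuration alone: the fact that compounds 2 and 4 differ only in the configuration as drawn. With 2 of 4 stereo elements differing, the read-out is a number 34.4 percentage points higher from compound 1 to compound 4 (beyond the scatter), a large step, whereas the steps with 3 of 4 differing, a number 20.4 percentage points higher from compound 1 to compound 2 (beyond the scatter) and the one just given, are both modest; among these three compounds, the size of the step therefore does not follow the count of changed stereo elements. Compound 4 now stands highest of the three stereoisomers, with its steps to both others beyond the scatter, and the large step again rests on configuration only: the fact that compounds 1 and 4 differ only in the configuration as drawn.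

Which single stereocentre carries the change stays open, since each of these steps alters at least two at once. Also open, from the compounds shown here alone, is whether this order of the stereoisomers holds when the carboxylic acid gives way to a methyl ester or a hydroxymethyl group, or when a longer chain sits on the amine nitrogen.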